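The source may hold more compounds than are shown below. What is called first, only, known or untested is meant among the compounds shown, and "the series" means these compounds.

Of the compounds shown here, three sharing one core have been measured in an assay on membranes from HEK293 cells for displacement of a labelled ligand from adenosine receptor A2b (Homo sapiens), read by scintillation counting, with a stated time of 30 min, tested at 1 uM; a lower number here means less inhibition, a higher number more inhibition at the concentration tested (going by the name of the read-out). Compound 1 `CC1=C(C(=O)C2CC2)C(c2ccoc2)NC(=O)N1` gives 10%, compound 2 `CCCC(=O)C1=C(C)NC(=O)NC1c1ccoc1` gives 22%, and compound 3 `CCSC(=O)C1=C(C)NC(=O)NC1c1ccoc1` gives 1%, the lowest of the three numbers; the steps into it were a number 9 percentage points lower from compound 1 to compound 3 (within the scatter) and a number 21 percentage points lower from compound 2 to compound 3 (beyond the scatter). Compound 4 `CC1=C(C(=O)OC2CCCCC2)C(c2ccoc2)NC(=O)N1` has not yet been measured and differs from compound 3 in one place: cyclohexyloxy in place of ethylsulfanyl on a carbonyl carbon. For the measured compounds named here, no measured step involves cyclohexyloxy, so only the two steps ending at ethylsulfanyl bear on this change, a number 9 percentage points lower from compound 1 to compound 3 (within the scatter) and a number 21 percentage points lower from compound 2 to compound 3 (beyond the scatter), and both point toward higher numbers when ethylsulfanyl is absent. For compound 4 a modest rise is therefore expected, a number 11 percentage points higher from compound 3 to compound 4 (beyond the scatter). Compound 4 is expected to give about 12% in this assay, within 0% to 35%.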

Compound 4, a percentage reported as inhibition, at one concentration (the size of the read-out at that concentration, not a potency): 4%
Beside the measured number, compound 4's estimate is 8 percentage points above it; measured number inside the range.
By their numbers in this assay, from the lowest: compounds 3, 4 and 1 (each within the scatter of the next); then compound 2.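

At this carbonyl carbon, cyclohexyloxy brings 7 heavy atoms and a six-membered ring where ethylsulfanyl has 3 heavy atoms and no ring, yet the result is a number 3 percentage points higher from compound 3 to compound 4 (within the scatter) and the two groups cannot be told apart. The other comparisons give a number 6 percentage points lower from compound 1 to compound 4 (within the scatter) and a number 18 percentage points lower from compound 2 to compound 4 (beyond the scatter) so that, of the four groups, only propyl stands clear of the two groups joined through oxygen or sulfur, while cyclopropyl stays within the scatter of both. No evidence is available to explain these results. On these data alone, what remains open is whether an amine or a longer chain at this carbonyl carbon would reach beyond the number for propyl.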